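Ester side-chain variation on the shared lactone core

A few compounds are considered here, and "the series" means these few. Any claim that something is new, unique, unknown or untested is made for them only; others in the source may bear on it.

Compound 1 `CCC(CC)(CC)C(=O)O[C@H]1C[C@@H](C)C=C2C=C[C@H](C)[C@H](CC[C@@H]3C[C@@H](O)CC(=O)O3)C21` gives 1.4 nM in an assay for inhibition of 3-hydroxy-3-methylglutaryl-coenzyme A reductase (Rattus norvegicus); on this read-out lower numbers stand for stronger inhibition and higher numbers for weaker inhibition. Compound 2 `CC(C)CC(=O)O[C@H]1C[C@@H](C)C=C2C=C[C@H](C)[C@H](CC[C@@H]3C[C@@H](O)CC(=O)O3)C21` gives 5.4 nM, and compound 3 `C=C(C)CC(=O)O[C@H]1C[C@@H](C)C=C2C=C[C@H](C)[C@H](CC[C@@H]3C[C@@H](O)CC(=O)O3)C21` gives 2.9 nM; compound 3 thus stands second highest of the three numbers, nearest to compound 2 and furthest from compound 1. Compound 4 `CCC(C)(CC)C(=O)O[C@H]1C[C@@H](C)C=C2C=C[C@H](C)[C@H](CC[C@@H]3C[C@@H](O)CC(=O)O3)C21` carries the change (1-ethyl-1-methylpropyl in place of 2-methylprop-2-en-1-yl on a carbonyl carbon). The step of a 2.1-fold higher number from compound 1 to compound 3 (0.32 log units; beyond the scatter) bears on it directly, since compound 1 holds the closely related 1,1-diethylpropyl group; the step of a 3.9-fold higher number from compound 1 to compound 2 (0.59 log units; beyond the scatter) points the same way, while a 1.9-fold lower number from compound 2 to compound 3 (0.27 log units; within the scatter) lies within the scatter. A modest lower number is therefore expected. Compound 4 is estimated at 1.8 nM, with a range of 0.9 nM to 3.6 nM. The expected step is a 1.6-fold lower number from compound 3 to compound 4 (0.21 log units; within the scatter).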

Compound 4, half-maximal inhibitory concentration: 1.4 nM
The estimate for compound 4 lay 1.3-fold (0.11 log units) above the measured number; measured number inside the range.
By their numbers in this assay, from the lowest: compounds 1 and 4 (each within the scatter of the next); then compounds 3 and 2 (each within the scatter of the next).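

Replacing 2-methylprop-2-en-1-yl with 1-ethyl-1-methylpropyl on the carbonyl carbon gives a 2.1-fold lower number from compound 3 to compound 4 (0.32 log units; beyond the scatter) in this assay, and replacing isobutyl with it gives a 3.9-fold lower number from compound 2 to compound 4 (0.59 log units; beyond the scatter). Between the 1,1-diethylpropyl and 1-ethyl-1-methylpropyl groups there is no change at the digits printed from compound 1 to compound 4 (within the scatter), so these two groups cannot be told apart at this position. Nothing shown accounts for these steps.

Still open, on these data alone, is whether a smaller group such as tert-butyl would hold the number at this position. As far as these compounds go, the effect of a ring such as cyclohexyl, or of a chain carrying an amine, is equally open.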